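Swapping the Hydroxyphenyl Ring for a Dichlorophenyl Ring

The source may report more compounds than this note shows. Statements on the series, on what has been measured and on what is new or still open speak of the compounds shown alone.

compound 1 `O=C(Cc1csc2nc(-c3ccc(Br)cc3)cn12)N/N=C/c1ccccc1O`: 6030 nM
compound 2 `O=C(Cc1csc2nc(-c3ccc(Br)cc3)cn12)N/N=C/c1ccc(O)cc1`: 50100 nM
compound 3 `COc1cccc(OC)c1/C=N/NC(=O)Cc1csc2nc(-c3ccc(Br)cc3)cn12`: 16200 nM

In a functional assay on HT-29 cells (Homo sapiens) for inhibition, read by sulforhodamine B assay, with a stated time of 48 h (a lower number here means a stronger inhibitor of growth, a higher number a weaker inhibitor of growth), compound 1 gives the lowest of the three numbers; compound 3 lies a 2.7-fold higher number from compound 1 to compound 3 (0.43 log units; beyond the scatter) and compound 2 lies an 8.3-fold higher number from compound 1 to compound 2 (0.92 log units; beyond the scatter). Compound 4 `O=C(Cc1csc2nc(-c3ccc(Br)cc3)cn12)N/N=C/c1ccc(Cl)cc1Cl` is not yet measured and differs from compound 1 by 2,4-dichlorophenyl in place of 2-hydroxyphenyl on a carbon with a double bond to nitrogen. Among the measured compounds shown here, none of the measured compounds carries chlorine, so no step matches this change directly. The two measured departures from 2-hydroxyphenyl both raised the number, one modestly and one more strongly. A modest rise beyond the scatter is therefore expected for compound 4, that is a 1.7-fold higher number from compound 1 to compound 4 (0.22 log units; within the scatter). The estimate for compound 4 is 10000 nM, with a range from 3500 nM to 30000 nM.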

Compound 4, concentration for 50% growth inhibition: 40700 nM
Compound 4: middle estimate off by 4.1-fold (0.61 log units), on the low side; measured number above the stated range.
By their numbers in this assay, from the lowest: compound 1; then compound 3; then compounds 4 and 2 (each within the scatter of the next).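

The 2,4-dichlorophenyl ring gives a clear loss against 2-hydroxyphenyl (a 6.7-fold higher number from compound 1 to compound 4 (0.83 log units; beyond the scatter)), so this chlorine-bearing ring does not match compound 1 at this place. It also trails the 2,6-dimethoxyphenyl ring (a 2.5-fold higher number from compound 3 to compound 4 (0.40 log units; beyond the scatter)), while compound 2 and compound 4 cannot be told apart (a 1.2-fold lower number from compound 2 to compound 4 (0.09 log units; within the scatter)), so two quite different rings end up level. No measurement at hand gives a reason for these steps.

Still open, from the compounds shown here alone, is whether an amine in place of the hydroxyl would hold the number of compound 1. Also open, going by these compounds, is whether a single chlorine on the ring would behave like the pair.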